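The source may report more compounds than this note shows. Statements on the series, on what has been measured and on what is new or still open speak of the compounds shown alone.

Compound 1, whose structure is `NCCCCCOC[C@H]1O[C@@H](OCCc2c[nH]c3ccccc23)[C@H](OCc2ccccc2)C[C@@H]1OCc1ccccc1`, is one of two compounds with a number in an assay on isolated protein for binding affinity to somatostatin receptor type 2 (Homo sapiens); a higher number here means a weaker inhibitor, a lower number a stronger inhibitor. In this assay compound 1 gives 3100 nM, the lower of the two numbers; compound 2, `CO[C@@H]1O[C@H](COCCCCCN)[C@@H](OCc2ccccc2)[C@H](OCc2ccccc2)[C@H]1OCc1ccccc1`, gives 4600 nM. The two values lie within the scatter of repeated measurements, so neither compound can be called the stronger binder on these data.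

Compound 3, `NCCCCCOC[C@H]1O[C@@H](OCCc2c[nH]c3ccccc23)[C@H](OCc2c[nH]cn2)C[C@@H]1OCc1ccccc1`, is not yet measured. It differs from compound 1 in one place: 1H-imidazol-4-yl in place of phenyl on a saturated chain carbon bound to an oxygen on a saturated carbon. Among the measured compounds shown here, no measured pair shows this change, so nothing in the data fixes its size or direction. The account therefore rests on compound 1 alone. Compound 3 is expected to give about 3000 nM in this assay, with a range from 1000 nM to 9000 nM. The step this estimate implies, a 1.0-fold lower number from compound 1 to compound 3 (0.01 log units; within the scatter), is expected to stay within the scatter, with no direction claimed.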

Compound 3, inhibition constant: 4600 nM
Estimate against measurement, compound 3: 1.5-fold (0.19 log units) below; the range from low to high includes it.
By their numbers in this assay, from the lowest: compounds 1, 2 and 3 (each within the scatter of the next).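

In this assay the step is a 1.5-fold higher number from compound 1 to compound 3 (0.17 log units; within the scatter) and lies within the scatter. Among the compounds shown here, this gives the first measured reading for this place: 1H-imidazol-4-yl, with one hydrogen-bond donor and one hydrogen-bond acceptor, stands in place of phenyl, which has neither, and the numbers do not separate compound 1 from compound 3. Nothing available explains this result.

This single step leaves open whether any group at this place can move the number beyond the scatter, for example an amine or a carboxylic acid in place of the ring, or a longer chain carrying the phenyl. It also leaves open whether the same exchange of phenyl for 1H-imidazol-4-yl would give a similar step on another core.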